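The source may hold more compounds than are shown below. What is called first, only, known or untested is meant among the compounds shown, and "the series" means these compounds.

Measured compounds, with their values in a functional assay for inhibition, with Homo sapiens as the target (on this read-out lower numbers stand for stronger inhibition and higher numbers for weaker inhibition), as follows
- compound 1 `CCCCS(=O)(=O)N[C@@H](CNC(=O)c1ccc2c(c1)C(=O)N(CCC1CCNCC1)C2)C(=O)O` gives 14 nM; 9 nM (2 entries)
- compound 2 `CCCCCS(=O)(=O)N[C@@H](CNC(=O)c1ccc2c(c1)C(=O)N(CCC1CCNCC1)C2)C(=O)O` gives 9 nM

Within the data shown here, compound 2 has 9 nM as its only number, and one further entry for it carries no single number. The two entries of compound 1 (the several entries of compound 1 in this assay, 14 nM; 9 nM (2 entries)) agree within the usual scatter, and the number for compound 2 lies within the scatter of them.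

Compound 3 `O=C(NCc1ccccc1)N[C@@H](CNC(=O)c1ccc2c(c1)C(=O)N(CCC1CCNCC1)C2)C(=O)O` is still unmeasured. It differs from compound 2 by benzylcarbamoyl in place of pentylsulfonyl on an amine nitrogen with benzylcarbamoyl in place of pentylsulfonyl on an amine nitrogen. Among the measured compounds shown here, no measured pair covers this exchange, so the expectation is tentative: a modest loss of inhibition in this assay and a wide range. The expected change is a 2.8-fold higher number from compound 2 to compound 3 (0.44 log units; beyond the scatter) toward weaker inhibition. For compound 3 the estimated value is 25 nM with an expected range of 7 nM to 90 nM in this series.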

Compound 3, half-maximal inhibitory concentration: 10 nM
Beside the measured number, compound 3's estimate is 2.5-fold (0.40 log units) above it; the measured number falls inside the stated range.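

In this assay, benzylcarbamoyl in place of pentylsulfonyl on the amine nitrogen gives a 1.1-fold higher number from compound 2 to compound 3 (0.05 log units; within the scatter). Among these compounds, until now this position had been seen only with sulfonyl groups carrying open chains; the step shows that neither the sulfonyl nor the open chain is needed for a number in this range, since a six-membered aromatic ring of carbon only and a hydrogen-bond donor enter without a change beyond the scatter. The step is no larger than the spread between repeat entries of a single compound: the several entries of compound 1 in this assay, 14 nM; 9 nM (2 entries)

The exchange alters the linking group and the chain together, so the contribution of each stays unresolved; a benzylsulfonyl or a pentylcarbamoyl group on the same nitrogen would separate them. Going by these compounds, how far this position stays this flat with a fluorobenzylcarbamoyl or a longer chain also remains open.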